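Methylamino added to the shared core of compound 2

The compounds below may be only part of what the source reports. "The series", "measured", "known", "first", "only" and "open" are said of these compounds alone.

For the measured compounds named here, compound 2 `O=C(Nc1nnn[nH]1)c1cc(=O)c2ccccc2o1` is the only compound with a number in a functional assay on cells (Mast cell, Rattus norvegicus) for inhibition, with a stated time of 15 min; on this read-out higher numbers stand for an effect only at larger amounts of compound and lower numbers for an effect already at smaller amounts. In this assay compound 2 gives 0.08 ug/mL. Compound 1 `O=C(Nc1nccs1)c1cc(=O)c2ccccc2o1` is recorded only as a limit of the assay, > 18 ug/mL, not as a number. Going by the values given here, the change of 1H-tetrazol-5-yl in place of 1,3-thiazol-2-yl on the amide-type nitrogen gives an at least 220-fold lower number from compound 1 to compound 2 (2.35 log units; beyond the scatter), and the only evidence on that step is the limit of > 18 ug/mL in this assay, at which 1 of the 2 values shown sits.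

Compound 3 `CNc1c(C(=O)Nc2nnn[nH]2)oc2ccccc2c1=O` differs from compound 2 by methylamino in place of hydrogen on an aromatic carbon. Among the compounds with values here, the single measured step concerns the group on the amide-type nitrogen and leaves the aromatic carbon untouched, and the 1H-tetrazol-5-yl is kept in compound 3, so no measured step bears on this change. The expectation for this assay is therefore a step of no more than the scatter, in either direction. Compound 3 is estimated at 0.12 ug/mL, with a range from 0.02 ug/mL to 0.7 ug/mL. The estimated step is a 1.5-fold higher number from compound 2 to compound 3 (0.18 log units; within the scatter), expected to sit within the scatter.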

Compound 3, concentration for half-maximal effect: 0.4 ug/mL
Compound 3: the middle estimate sits 3.3-fold (0.52 log units) below what was measured; the measured number falls inside the stated range.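

For the compounds shown here, the earlier pair changed only the group on the amide-type nitrogen, so this is the first reading on the shared core itself: in this assay, methylamino in place of hydrogen on this aromatic carbon gives a 5.0-fold higher number from compound 2 to compound 3 (0.70 log units; beyond the scatter), which shows that the position, two atoms from the ring oxygen and ortho to the group of 8 heavy atoms, is not indifferent to substitution. The change is modest, and compound 3 still gives a number, 0.4 ug/mL, with the 1H-tetrazol-5-yl kept. Nothing measured here bears on the origin of this step, and the one available observation concerns a different part of the molecule.

From the compounds shown here alone, whether the step follows from the nitrogen, the methyl or simply from any group at this carbon stays open, since a primary amine, a hydroxyl, a plain methyl or a dimethylamino group at the same position would separate these readings. Also open, going by these compounds, is whether a longer chain on that nitrogen would move the number further, and whether the step would carry over to other groups on the amide-type nitrogen.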